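Aminophenyl for chlorophenyl on the hydrazide carbonyl

The source may hold more compounds than are shown below. What is called first, only, known or untested is meant among the compounds shown, and "the series" means these compounds.

Measured compounds:
compound 1 `O=C(N/N=C/C1=C(Cl)c2ccccc2CCC1)c1cccc(Cl)c1`: 19200 nM
compound 2 `Nc1ccccc1C(=O)N/N=C/C1=C(Cl)c2ccccc2CCC1`: a limit only, > 100000 nM
compound 3 `Cc1cc2c(cc1C)C(Cl)=C(/C=N/NC(=O)c1cccc(Cl)c1)CCC2`: 770 nM

All numbers come from a functional assay on HeLa cells (Homo sapiens) for inhibition, read by sulforhodamine B assay, with a stated time of 48 h; a higher number here means a weaker inhibitor of growth, a lower number a stronger inhibitor of growth. In this assay compound 1 gives 19200 nM. For compound 2 the assay gives no number but a limit, > 100000 nM; this is the limit of > 100000 nM in this assay, at which 1 of the 3 values shown sits. The change between them is 2-aminophenyl in place of 3-chlorophenyl on a carbonyl carbon, and it made an at least 5.2-fold higher number from compound 1 to compound 2 (0.71 log units; beyond the scatter), a step whose true size is open because compound 2 sits at the limit. Compound 3 carries a different core, and the difference between the two cores is not broken down here; in this assay compound 3 gives 770 nM, the lowest of the two numbers shown.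

Compound 4 `Cc1cc2c(cc1C)C(Cl)=C(/C=N/NC(=O)c1ccccc1N)CCC2` is not yet measured. It differs from compound 3 by 2-aminophenyl in place of 3-chlorophenyl on a carbonyl carbon, the same change as from compound 1 to compound 2 at the same place. The step is expected to be a 10-fold higher number from compound 3 to compound 4 (1.02 log units; beyond the scatter), resting on an at least 5.2-fold higher number from compound 1 to compound 2 (0.71 log units; beyond the scatter), with the lower starting number of compound 3 leaving room for a number rather than a limit. Compound 4 is therefore estimated at 8000 nM, with a range from 2500 nM to 40000 nM.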

Compound 4, concentration for 50% growth inhibition: > 100000 nM
Compound 4: no number, only a limit; the forecaster's own chance of this, stated with the estimate: 10%; middle value at least 12-fold (1.09 log units) from the limit.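

In this assay compound 4 stands at a limit, > 100000 nM, and not at a number. Putting 2-aminophenyl in place of 3-chlorophenyl on the carbonyl carbon gives an at least 120-fold higher number from compound 3 to compound 4 (2.11 log units; beyond the scatter), so on both cores the change raises the number beyond the scatter, and the direction of the step carries over in these two cases. No size of the step carries over from one core to the other, and with compound 2 and compound 4 both at the limit, the two cores cannot be ranked when they bear 2-aminophenyl: the same change on two cores in this assay, an at least 5.2-fold higher number (0.71 log units; beyond the scatter) from compound 1 to compound 2 and an at least 120-fold higher number (2.11 log units; beyond the scatter) from compound 3 to compound 4; the limit leaves it open whether they differ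

Open, going by these compounds, is whether a hydroxyl, a methoxy group or an acetamide on the phenyl ring would behave as the amine does on either core. Also open, on these data alone, is where an unsubstituted phenyl on the carbonyl carbon would fall relative to the 3-chlorophenyl compounds.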